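The source may hold more compounds than are shown below. What is called first, only, known or untested is meant among the compounds shown, and "the series" means these compounds.

Among the compounds with values here, compound 3, with the structure `Cc1ccc(C(=O)Nc2cccc(-c3oc4cc(-c5ccc(F)cc5)ccc4c(=O)c3O)c2)cc1`, gives the lowest number among the three compounds measured so far. In a functional assay on MDA-MB-231 cells (Homo sapiens) for antiproliferative activity, read by CCK-8 assay, with a stated time of 72 h (a lower number here means a stronger inhibitor, a higher number a weaker inhibitor), compound 3 gives 4350 nM. Its closest neighbour is compound 1, `O=C(Nc1cccc(-c2oc3cc(-c4ccc(F)cc4)ccc3c(=O)c2O)c1)c1ccccc1F`, which in this assay gives 7240 nM; the step of a 1.7-fold lower number from compound 1 to compound 3 (0.22 log units; within the scatter) lies within the scatter, so these two cannot be told apart. Compound 2, `COc1ccc(C(=O)Nc2cccc(-c3oc4cc(-c5ccc(F)cc5)ccc4c(=O)c3O)c2)cc1`, gives 16500 nM in this assay, and the step of a 3.8-fold lower number from compound 2 to compound 3 (0.58 log units; beyond the scatter) is beyond the scatter.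

Compound 4, `O=C(Nc1cccc(-c2oc3cc(-c4ccc(F)cc4)ccc3c(=O)c2O)c1)c1ccc(F)cc1F`, has not yet been measured. It differs from compound 3 in one place: 2,4-difluorophenyl in place of 4-methylphenyl on a carbonyl carbon. The step that bears most directly on this change is a 1.7-fold lower number from compound 1 to compound 3 (0.22 log units; within the scatter), where a fluorine-bearing phenyl and a methyl-bearing phenyl on the same carbonyl carbon gave numbers within the scatter of each other. Within the data shown here, the second fluorine in compound 4 has no counterpart among the measured compounds, so its effect is unknown. The expectation is therefore a small step, if any, and the estimated change a 1.4-fold higher number from compound 3 to compound 4 (0.14 log units; within the scatter) stays close to the scatter. Compound 4 is expected to give about 6000 nM in this assay, within a range from 2500 nM to 15000 nM.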

Compound 4, half-maximal inhibitory concentration: 11200 nM
Estimate against measurement, compound 4: 1.9-fold (0.27 log units) below; low and high end bracket the measured number.
By their numbers in this assay, from the lowest: compounds 3, 1, 4 and 2 (each within the scatter of the next, the first and the last beyond it).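

Going from 4-methylphenyl to 2,4-difluorophenyl on this carbonyl carbon is a 2.6-fold higher number from compound 3 to compound 4 (0.41 log units; beyond the scatter) in this assay and shows that a fluorinated phenyl here can be told apart from 4-methylphenyl, which the pair of compound 1 and compound 3 could not show. Yet fluoro in place of hydrogen on an aromatic carbon is only a 1.5-fold higher number from compound 1 to compound 4 (0.19 log units; within the scatter) and 2,4-difluorophenyl in place of 4-methoxyphenyl is a 1.5-fold lower number from compound 2 to compound 4 (0.17 log units; within the scatter) so neither of these two steps can be read as a real change, and the second fluorine on its own has no effect that can be told from the scatter. No measurement at hand speaks to the reason for these differences.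

The compounds shown all carry a substituted phenyl on this carbonyl carbon, so it remains open whether an amine or a carboxylic acid on that phenyl, or a longer chain in its place, would move the number in either direction. On these data alone, it also remains open whether an ethyl group in place of the methyl of compound 3 would keep the number where it is.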